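Fluoro on the phenyl: cytotoxicity expectation for compound 4

The compounds below may be only part of what the source reports. "The series", "measured", "known", "first", "only" and "open" are said of these compounds alone.

Measured in an ADME assay on THP-1 cells (Homo sapiens) for cytotoxicity; on this read-out lower numbers stand for higher toxicity in this test and higher numbers for lower toxicity in this test:
- compound 1 `CC(C)(O)CNc1c(-c2ccccn2)nc2ccccn12` gives > 50000 nM, a limit of the test.
- compound 2 `c1ccc(-c2nc3ccccn3c2NC2CCNC2)nc1` gives > 50000 nM, a limit of the test.
- compound 3 `c1ccc(Nc2c(-c3ccccn3)nc3ccccn23)cc1` gives 6690 nM.

Within the data shown here, compound 3 is the only compound with a number; the other two sit at the limit of > 50000 nM in this assay, at which 2 of the 3 values shown sit. The two steps that reach compound 3, an at least 7.4-fold lower number from compound 1 to compound 3 (0.87 log units; beyond the scatter) and an at least 7.4-fold lower number from compound 2 to compound 3 (0.87 log units; beyond the scatter), are both at least modest and both replace the group on the ring nitrogen with phenyl.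

Compound 4 `Fc1cccc(Nc2c(-c3ccccn3)nc3ccccn23)c1` differs from compound 3 by fluoro in place of hydrogen on an aromatic carbon. Among the measured compounds shown here, none of the measured steps touches the phenyl itself; all three swap the whole group on the ring nitrogen, so no measured step bears directly on this change. In this assay compound 4 is therefore expected to sit close to compound 3, with a step of a 1.1-fold lower number from compound 3 to compound 4 (0.05 log units; within the scatter) not beyond the scatter. The estimate for compound 4 in this assay is 6000 nM, within 2500 nM to 15000 nM.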

Compound 4, half-maximal cytotoxic concentration: > 50000 nM
Compound 4 was reported as a limit; the forecaster's own chance of this, stated with the estimate: 10%; middle value at least 8.3-fold (0.92 log units) from the limit.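

Fluoro in place of hydrogen on the phenyl, meta to a large group, gives an at least 7.4-fold higher number from compound 3 to compound 4 (0.87 log units; beyond the scatter) in this assay, so a change of one atom on this ring moves the read-out beyond the scatter, where earlier only swaps of the whole group on the ring nitrogen had done so. Among these compounds, compound 4 gives > 50000 nM, which is a limit, and it joins the other compounds at the edge of the test, leaving compound 3 as the only one with a number: the limit of > 50000 nM in this assay, at which 3 of the 4 values shown sit. The steps from compound 1 and compound 2 to compound 4 cannot be read.

Whether this step belongs to fluoro itself or to its place on the ring stays open, as the compounds shown hold no chloro, methyl or methoxy on the phenyl and no fluoro elsewhere on it. From the compounds shown here alone, how far compound 4 lies from compound 1 and compound 2 also stays open.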